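Solubility notes on the shared core series

The source may report more compounds than this note shows. Statements on the series, on what has been measured and on what is new or still open speak of the compounds shown alone.

Compound 2 `FC(F)(F)c1ccc(Nc2cc3[nH]c(-c4cccc(C(F)(F)F)c4)nc3cn2)nc1` returns only a limit in a physicochemical assay for solubility, using the shake flask method, measured as kinetic solubility, with a stated time of 20 h, at pH 2 (a higher number here means a more soluble compound, a lower number a less soluble compound), < 5000 nM, which is not a number. Compound 1 `COc1ccc(Nc2cc3[nH]c(-c4cccc(C(F)(F)F)c4)nc3cn2)nc1` likewise gives the limit < 5000 nM in this assay. Compound 3 `O=C(O)c1ccc(Nc2cc3[nH]c(-c4cccc(C(F)(F)F)c4)nc3cn2)nc1` also stops at the limit < 5000 nM there. The measured steps a step that the two limits leave unreadable from compound 1 to compound 2, a step that the two limits leave unreadable from compound 1 to compound 3 and a step that the two limits leave unreadable from compound 2 to compound 3 accordingly carry no readable size, as all three values sit at the limit of < 5000 nM in this assay, at which 3 of the 3 values shown sit. Compound 4 `FC1(F)CC(c2nc3cnc(Nc4ccc(C(F)(F)F)cn4)cc3[nH]2)C1` is not yet measured; its change from compound 2 is 3,3-difluorocyclobutyl in place of 3-(trifluoromethyl)phenyl on an aromatic carbon. Among the compounds with values here, no measured step bears on this change, so neither size nor direction can be read from the series. Compound 4 is expected to give about 8000 nM in this assay, within a range of 2000 nM to 40000 nM, with a real chance of another limit. The step is thus estimated at an at least 1.6-fold higher number from compound 2 to compound 4 (0.20 log units; that floor lies within the scatter).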

Compound 4, solubility: 181000 nM
For compound 4 the middle estimate is 23-fold (1.35 log units) below the measured one, and the stated range ends below it.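

Within the data shown here, the place on the aromatic carbon between two ring nitrogen atoms gives the first readable step: 3,3-difluorocyclobutyl in place of 3-(trifluoromethyl)phenyl is an at least 36-fold higher number from compound 2 to compound 4 (1.55 log units; beyond the scatter) in this assay. Compound 2 gives < 5000 nM, which is a limit, so this size is only a floor. The steps among methoxy, trifluoromethyl and carboxy cannot be read, and values in this series mostly stop at one limit: the limit of < 5000 nM in this assay, at which 3 of the 4 values shown sit.

Open, on these data alone, is whether the step holds with methoxy or carboxy in place of the trifluoromethyl of compound 4. Also open, as far as these compounds go, is how plain cyclobutyl or an amine such as morpholine would read at this place.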